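A few compounds are considered here, and "the series" means these few. Any claim that something is new, unique, unknown or untested is made for them only; others in the source may bear on it.

Compound 2, `COc1ccc(/C=C(/SCc2ccc(Cl)cc2)C(=O)c2ccc(Br)cc2)cc1`, sits at the lower end of a small set. In a functional assay on DU-145 cells (Homo sapiens) for inhibition, read by trypan blue exclusion, with a stated time of 96 h (a lower number here means a stronger inhibitor of growth, a higher number a weaker inhibitor of growth), compound 2 gives 10000 nM, and compound 3, `COc1ccc(/C=C(/SCc2ccc(Cl)cc2)C(=O)c2ccc(Cl)cc2)cc1`, gives 10000 nM, the two standing level at the digits printed, together the lowest of the three numbers. Compound 1, `COc1ccc(/C=C(/Sc2ccc(C)cc2)C(=O)c2ccc(Br)cc2)cc1`, gives 50000 nM, the furthest from compound 2. The two measured steps are a 5.0-fold lower number from compound 1 to compound 2 (0.70 log units; beyond the scatter), a modest step, and no change at the digits printed from compound 2 to compound 3 (within the scatter), a change that did nothing beyond the scatter.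

Compound 4, `CN(C)c1ccc(/C=C(/SCc2ccc(Cl)cc2)C(=O)c2ccc(Br)cc2)cc1`, differs from compound 2 in one place: dimethylamino in place of methoxy on an aromatic carbon. Neither measured step touches this position; both concern the sulfur substituent or the halogen on the benzoyl ring, so nothing here speaks directly to what a change at the methoxy-bearing ring will do. Among the compounds with values here, the only guidance is that the one exchange of a small group for a related small group, compound 2 to compound 3, left the number unchanged. Compound 4 is therefore expected to stay close to compound 2, with a step of no change at the digits printed from compound 2 to compound 4 (within the scatter) or none beyond the scatter, and an estimated value of 10000 nM, within 3000 nM to 30000 nM.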

Compound 4, concentration for 50% growth inhibition: 10000 nM
The estimate for compound 4 equals the measured number at the digits printed, and the stated range covers the measured number.
By their numbers in this assay, from the lowest: compounds 2, 3 and 4 (each within the scatter of the next); then compound 1.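

In this assay the change from 4-methoxyphenyl to 4-(dimethylamino)phenyl gives no change at the digits printed from compound 2 to compound 4 (within the scatter) as its result. Within the data shown here, this is the first reading at this position, on an aromatic carbon para to a large group, since the earlier steps concerned only the sulfur substituent and the halogen, and it shows that this one exchange leaves the number where it was. No measurement available here explains why the number holds.

The compounds shown leave open whether the position would tolerate a group of another kind, such as a carboxylic acid, a primary amine or a longer chain like butoxy, as readily as dimethylamino. They also leave open whether dimethylamino would behave the same way with the 4-methylphenyl on sulfur of compound 1 in place of the 4-chlorobenzyl.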